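Two ring stereocentres inverted in a peroxide acid

A few compounds are considered here, and "the series" means these few. Any claim that something is new, unique, unknown or untested is made for them only; others in the source may bear on it.

Compound 2 `C=C1CCCC(C)(C)C1CC[C@@]1(C)CC[C@H]([C@@H](C)C(=O)O)OO1` carries a free carboxylic acid where compound 1 `C=C1CCCC(C)(C)C1CC[C@]1(C)CC[C@H]([C@@H](C)C(=O)OC)OO1` carries a methyl ester. In a functional assay on MOLT-4 cells (Homo sapiens) for inhibition (a higher number here means a weaker inhibitor of growth, a lower number a stronger inhibitor of growth), compound 2 gives 2160 nM, the lower of the two numbers available, and compound 1 gives 7040 nM, a gap that lies beyond the usual scatter of this assay. Within the data shown here, no step between these two has been characterised further, so their two values are all that can be said of them.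

Compound 3 `C=C1CCCC(C)(C)C1CC[C@]1(C)CC[C@@H]([C@@H](C)C(=O)O)OO1` keeps every atom and bond of compound 2 and differs only in configuration: the two compounds have the same atoms and bonds; at least one stereo element is drawn with a configuration in one of them and without one in the other: 2 of 4 stereo elements differ; a stereocentre at a saturated ring carbon is drawn S in compound 2 and R in compound 3; a stereocentre at a saturated ring carbon is drawn R in compound 2 and S in compound 3. Among the measured compounds shown here, no measured pair shows what such a change in configuration does here, so the direction is open. A change at two ring stereocentres within the same framework could leave growth inhibition roughly where it is or weaken it noticeably; a gain is judged less likely.

Compound 3 is therefore expected to give about 3500 nM in this assay, in a range from 1200 nM to 12000 nM. That estimate corresponds to a step of a 1.6-fold higher number from compound 2 to compound 3 (0.21 log units; within the scatter), a modest move towards weaker growth inhibition, not far beyond the scatter.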

Compound 3, concentration for 50% growth inhibition: 7430 nM
Estimate against measurement, compound 3: 2.1-fold (0.33 log units) below; measured number inside the range.
By their numbers in this assay, from the lowest: compound 2; then compounds 1 and 3 (each within the scatter of the next).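

Among these compounds, the pair gives the first reading of configuration on this framework: with atoms and bonds unchanged, this assay records a 3.4-fold higher number from compound 2 to compound 3 (0.54 log units; beyond the scatter), so growth inhibition weakens beyond the scatter. The carboxylic acid is present in both compounds, so a free acid alone does not fix the number, and the arrangement at the two ring stereocentres also counts in this series. The only structural evidence bearing on the pair concerns how the two are drawn, and it ties the step to the place where they differ: the fact that one of compounds 2 and 3 is drawn with a defined configuration and the other without, at the place where they differ

Both ring stereocentres change together in this step, so the share of each in the loss remains unknown, and the compounds shown do not say whether inverting a single centre would give a smaller step, the same step or none. From the compounds shown here alone, it also remains open whether the same configurational preference would hold if an amide or an ethyl ester took the place of the carboxylic acid.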